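Methyl to methoxy on the fused ring: solubility notes

A few compounds are considered here, and "the series" means these few. Any claim that something is new, unique, unknown or untested is made for them only; others in the source may bear on it.

Measured so far in a physicochemical assay for solubility, at pH 7.4; a higher number here means a more soluble compound, a lower number a less soluble compound:
compound 1, `Cc1ccc2nc(NC(C)C)nc(NCc3ccco3)c2c1`, gives <= 20000 nM, which is a limit of the assay rather than a number.
compound 2, `Cc1cccc2nc(NC(C)C)nc(NCc3ccco3)c12`, gives <= 10000 nM, again a limit of the assay.
compound 3, `COc1ccc2nc(NC(C)C)nc(NCc3ccco3)c2c1`, gives >= 30000 nM, also a limit of the assay.

All three values sit at limits, one at each of the limit of <= 10000 nM in this assay, at which 1 of the 3 values shown sits, the limit of <= 20000 nM in this assay, at which 1 of the 3 values shown sits, and (the limit of >= 30000 nM in this assay, at which 1 of the 3 values shown sits), so every step here is a floor, not a measured size. Going by the values given here, the one step that can be read is an at least 1.5-fold higher number from compound 1 to compound 3 (0.17 log units; that floor lies within the scatter), brought about by methoxy in place of methyl on an aromatic carbon. Compound 1 and compound 2 share the same atoms joined differently; how the two cores differ is not broken down here.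

Compound 4, `COc1cccc2nc(NC(C)C)nc(NCc3ccco3)c12`, is not yet measured. It stands to compound 2 as compound 3 stands to compound 1: methoxy in place of methyl on an aromatic carbon. It is the same kind of change, not the same: in compound 3 the place is meta to a fused ring and para to a fused ring, whereas in compound 4 it is ortho to a fused ring and meta to a fused ring.

Going from compound 2, the expectation rests on compound 2 giving <= 10000 nM and on the step of an at least 1.5-fold higher number from compound 1 to compound 3 (0.17 log units; that floor lies within the scatter), whose floor lies within the scatter. A step of an at least 2.0-fold higher number from compound 2 to compound 4 (0.30 log units; that floor lies within the scatter) in this assay is expected, with a fair chance that the assay again reports only a limit. The estimate for compound 4 is 20000 nM, between 6000 nM and 60000 nM.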

Compound 4, solubility: <= 20000 nM
Compound 4 gave a limit, no number (the forecaster's own chance of this, stated with the estimate: 50%); the middle value sits exactly at the limit.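

In this assay compound 4 gives <= 20000 nM, which is a limit of the assay. Compound 2 also sits at a limit, so the step from compound 2 to compound 4 cannot be read. The compounds shown leave open whether methoxy in place of methyl, ortho to a fused ring and meta to a fused ring, changes the value at all, and by how much.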